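Steryl-sulfatase inhibition in a sulfamate benzamide series

The source may hold more compounds than are shown below. What is called first, only, known or untested is meant among the compounds shown, and "the series" means these compounds.

Measured compounds and their readings in an assay on HEK293 cells for inhibition of Steryl-sulfatase (Homo sapiens), tested at 1 uM; on this read-out higher numbers stand for a stronger effect at the one concentration tested and lower numbers for a weaker effect:
compound 1 `NS(=O)(=O)Oc1ccc2c(c1)CN(C(=O)c1ccc(N(CCCO)Cc3ccccc3)cc1)CC2` gives 64.3%
compound 2 `CCCN(Cc1ccccc1)c1cccc(C(=O)N2CCc3ccc(OS(N)(=O)=O)cc3C2)c1` gives 67.4%
compound 3 `CCCN(Cc1ccccc1)c1ccc(C(=O)N2CCc3ccc(OS(N)(=O)=O)cc3C2)cc1` gives 94.3%

Compound 3 and compound 1 differ in one place: hydroxy in place of hydrogen on a saturated chain carbon, three bonds along the chain from a nitrogen on an aromatic ring. That change gave a number 30 percentage points lower from compound 3 to compound 1 (beyond the scatter). Compound 2 and compound 3 are made of the same atoms joined differently; the difference between the two cores is not broken down here. Compound 4 `NS(=O)(=O)Oc1ccc2c(c1)CN(C(=O)c1cccc(N(CCCO)Cc3ccccc3)c1)CC2` is not yet measured. It stands to compound 2 as compound 1 stands to compound 3: hydroxy in place of hydrogen on a saturated chain carbon, three bonds along the chain from a nitrogen on an aromatic ring, the same change at the same place. Within the data shown here, the only basis for an expectation is the single measured step, from compound 3 to compound 1, which rests on one pair, so its transfer to the core of compound 2 is uncertain. The expected step is a number 25.4 percentage points lower from compound 2 to compound 4 (beyond the scatter). Compound 4 is estimated at 42%, within 25% to 60%.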

Compound 4, a percentage reported as inhibition, at one concentration (the size of the read-out at that concentration, not a potency): 37.3%
Compound 4: the middle estimate sits 4.7 percentage points above what was measured; the range from low to high includes it.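

In this assay, going from propyl to 3-hydroxypropyl gives a number 30.1 percentage points lower from compound 2 to compound 4 (beyond the scatter). The step keeps its size when carried from one core to the other: the same change on two cores in this assay, a number 30 percentage points lower (beyond the scatter) from compound 3 to compound 1 and a number 30.1 percentage points lower (beyond the scatter) from compound 2 to compound 4, 0.1 percentage points apart, within the scatter of two such steps

This agreement rests on two pairs, on two cores, at a single concentration, so it shows transfer between these cores only; it gives neither a change in potency nor a reason for the drop, and it does not extend to other cores.

From the compounds shown here alone, whether the drop belongs to the hydroxy itself or to its place on the chain stays open. A 2-hydroxyethyl chain, a longer chain, or a methoxy, an amine or a carboxylic acid in place of the hydroxy would bear on that.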